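From Hydroxyethyl Amide to Ethyl Ester on the Shared Core

The compounds below may be only part of what the source reports. "The series", "measured", "known", "first", "only" and "open" are said of these compounds alone.

Compound 3 `Cc1oc2ncnc(Nc3cccc(Br)c3)c2c1C(=O)NCCO` is the only one of the three measured compounds that yields a number: in a functional assay on A549 cells (Homo sapiens) for cytotoxicity, read by MTT assay, with a stated time of 72 h (a lower number here means a stronger inhibitor, a higher number a weaker inhibitor), compound 3 gives 17400 nM. Compound 1 `CCOC(=O)c1c(C)oc2ncnc(Nc3cccc(Cl)c3)c12` carries chloro and an ethoxycarbonyl group on the shared core, and in this assay compound 1 sits at a limit, > 1000000 nM. Compound 2 `C#Cc1cccc(Nc2ncnc3oc(C)c(C(=O)OCC)c23)c1` has ethynyl in place of chloro on an aromatic carbon, and in this assay compound 2 likewise sits at a limit, > 1000000 nM. The step that the two limits leave unreadable from compound 1 to compound 2 is therefore not readable.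

Compound 4 `CCOC(=O)c1c(C)oc2ncnc(Nc3cccc(Br)c3)c12` is compound 3 with ethoxy in place of (2-hydroxyethyl)amino on a carbonyl carbon. For the measured compounds named here, no measured pair isolates this exact change, so its size cannot be taken from a directly comparable step. Going by the values given here, what the data do show is the limit of > 1000000 nM in this assay, at which 2 of the 3 values shown sit, and both of those compounds are the ones bearing the ethoxycarbonyl group that enters here, while compound 3, the only compound bearing the (2-hydroxyethyl)carbamoyl group, is the only one with a number. On that basis compound 4 is expected to lose considerably, with the step of a 29-fold higher number from compound 3 to compound 4 (1.46 log units; beyond the scatter) estimated as a large weakening, and a fair chance that only a limit is reported. The estimate for compound 4 in this assay is 500000 nM, within 50000 nM to 2000000 nM.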

Compound 4, half-maximal inhibitory concentration: > 1000000 nM
Compound 4: a limit, no number (the forecaster's own chance of this, stated with the estimate: 65%); middle value at least 2.0-fold (0.30 log units) away from the limit.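

For the compounds shown here, with compound 4, the change on this carbonyl carbon is seen for the first time on its own, with bromo kept in place: in this assay ethoxy in place of (2-hydroxyethyl)amino gives an at least 57-fold higher number from compound 3 to compound 4 (1.75 log units; beyond the scatter) and is a large loss, on a pair that differs in this one place only. Compound 1 and compound 2 could not show this, since each also carries a different aromatic substituent from compound 3. For compound 4 the value > 1000000 nM is a limit, not a number, so the step gives only a minimum, and all the compounds shown with ethoxycarbonyl now sit at that limit: the limit of > 1000000 nM in this assay, at which 3 of the 4 values shown sit.

The steps among compound 1, compound 2 and compound 4 cannot be read, so chloro, ethynyl and bromo stay unranked when ethoxycarbonyl is present. As far as these compounds go, whether a carboxylic acid, a plain methyl amide or a longer chain ending in an amine on this carbonyl carbon would give a number in this assay remains open, as does which part of (2-hydroxyethyl)carbamoyl matters.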